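Replacing methyl with isopropyl on a low-nanomolar compound

A few compounds are considered here, and "the series" means these few. Any claim that something is new, unique, unknown or untested is made for them only; others in the source may bear on it.

Compound 1 `CC1=NC(C)=C(C(=O)OCCCN2C(=O)c3ccccc3S2(=O)=O)C(c2cccc([N+](=O)[O-])c2)/C1=C(\O)OC(C)C`: 1 nM
Compound 2 `CO/C(O)=C1\C(C)=NC(C)=C(C(=O)OCCCN2C(=O)c3ccccc3S2(=O)=O)C1c1ccccc1Cl`: 1.8 nM

In a functional assay (aorta) with Oryctolagus cuniculus as the target (on this read-out lower numbers stand for stronger inhibition and higher numbers for weaker inhibition), compound 1 gives 1 nM and compound 2 gives 1.8 nM. Compound 2 therefore stands within the usual scatter of compound 1, and the two values cannot be told apart.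

Compound 3 `CC1=NC(C)=C(C(=O)OCCCN2C(=O)c3ccccc3S2(=O)=O)C(c2ccccc2Cl)/C1=C(\O)OC(C)C` comes from compound 2 through a single structural change: isopropyl in place of methyl on an oxygen on an unsaturated carbon. In words, isopropyl takes the place of methyl on an oxygen on an unsaturated carbon, so a methoxy group becomes an isopropoxy group.

Among the measured compounds shown here, no two measured compounds differ by this change alone, so the data give no direct measure of its effect. The starting point for the expectation is compound 2 at 1.8 nM. No step beyond the scatter is expected in this assay, and neither direction is favoured. The estimated step is a 1.2-fold lower number from compound 2 to compound 3 (0.08 log units; within the scatter). For compound 3 the estimated value is 1.5 nM, with an expected range from 0.5 nM to 5 nM.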

Compound 3, half-maximal inhibitory concentration: 1.3 nM
Estimate against measurement, compound 3: 1.2-fold (0.06 log units) above; low and high end bracket the measured number.
By their numbers in this assay, from the lowest: compounds 1, 3 and 2 (each within the scatter of the next).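

Read through this assay, isopropyl in place of methyl on an oxygen on an unsaturated carbon gives a 1.4-fold lower number from compound 2 to compound 3 (0.14 log units; within the scatter) and so leaves methoxy and isopropoxy indistinguishable at this position. Compounds 1 and 2 differ in two places, but compound 3 separates those changes: with the isopropoxy group held constant, 2-chlorophenyl in place of 3-nitrophenyl on a saturated ring carbon gives a 1.3-fold higher number from compound 1 to compound 3 (0.11 log units; within the scatter) and also stays inside the usual scatter. Neither change therefore produces a measurable shift in this read-out, although nothing available explains why the values lie so close together.

Going by these compounds, it remains open whether a tert-butyl group, a longer chain or a chain ending in an amine on this oxygen would also leave the number within the scatter. The same question stands for the saturated ring carbon, where an unsubstituted phenyl or a pyridine ring could test how far the tolerance seen with 2-chlorophenyl and 3-nitrophenyl extends.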